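A few compounds are considered here, and "the series" means these few. Any claim that something is new, unique, unknown or untested is made for them only; others in the source may bear on it.

Measured compounds:
- compound 1, `COC(=O)/C1=C\CC[C@@H]2O[C@H]2CC/C(C(=O)OC)=C\C=C(/C(C)C)CC1`: 19 ug/mL
- compound 2, `COC(=O)/C1=C\[C@@H]2O[C@@]2(C(C)C)CC/C(C(=O)OC)=C/CC[C@@H]2O[C@H]2CC1`: 5 ug/mL
- compound 3, `COC(=O)/C1=C/C=C(/C(C)C)CCC2=CCC[C@](C)(OC2=O)[C@H](OC(C)=O)CC1`: 4 ug/mL

In a functional assay on KB cells (Homo sapiens) for cytotoxicity (on this read-out lower numbers stand for stronger inhibition and higher numbers for weaker inhibition), compound 3 gives 4 ug/mL, the lowest of the three numbers. The nearest number is that of compound 2, which in this assay gives 5 ug/mL, a gap that lies within the scatter, so no order between compound 3 and compound 2 can be read from these two values. The furthest is compound 1, which in this assay gives 19 ug/mL, a gap beyond the scatter.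

Compound 4, `COC(=O)/C1=C\C=C(\C(C)C)CCC2=CCC[C@](C)(OC2=O)[C@@H](OC(C)=O)CC1`, has not yet been measured. Its relation to compound 3 is the two compounds have the same atoms and bonds and differ only in configuration as drawn: 2 of 4 stereo elements differ; a stereocentre at a saturated ring carbon is drawn R in compound 3 and S in compound 4; a double bond is drawn E in compound 3 and Z in compound 4. Going by the values given here, no pair of measured compounds differs by a change of this kind, so nothing among the three numbers tells how large a step to expect in this assay from such a difference in configuration alone. In the absence of any guide, a step from compound 3 to compound 4 of a 1.5-fold higher number from compound 3 to compound 4 (0.18 log units; within the scatter) is expected, with a wide range on either side. Compound 4 is therefore estimated to give 6 ug/mL in this assay, between 2 ug/mL and 20 ug/mL.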

Compound 4, half-maximal inhibitory concentration: 5 ug/mL
For compound 4 the middle estimate is 1.2-fold (0.08 log units) above the measured one; measured number inside the range.
By their numbers in this assay, from the lowest: compounds 3, 2 and 4 (each within the scatter of the next); then compound 1.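

In this assay, the change in configuration gives a 1.3-fold higher number from compound 3 to compound 4 (0.10 log units; within the scatter), so this step cannot be told apart from the scatter of repeated measurements. Going by these compounds alone, this is the first step that can be read directly, and nothing else in the structures can account for the values, as the comparison rests on a single kind of difference: the fact that compounds 3 and 4 differ only in the configuration as drawn. For this pair, then, changing the saturated ring stereocentre from R to S together with the double bond from E to Z leaves no measurable mark on the read-out, although the step covers only this one combination.

The two stereo elements differ together, so the pair cannot show what either change would do alone, or whether two separate effects offset each other. The compounds also leave open how this read-out would respond if a free hydroxyl or an amine stood in place of the acetoxy group, and whether either configuration would then matter.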